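Compound 3 to compound 4: a flat series so far

The compounds below may be only part of what the source reports. "The series", "measured", "known", "first", "only" and "open" are said of these compounds alone.

Compound 1 `O=C(Nc1ccc(S(=O)(=O)Nc2cc(F)c(O)c(F)c2)cc1)c1ccccc1`: 68600 nM
Compound 2 `COc1ccc(C(=O)Nc2ccc(S(=O)(=O)Nc3cc(F)c(O)c(F)c3)cc2)cc1`: 70700 nM
Compound 3 `O=S(=O)(Nc1cc(F)c(O)c(F)c1)c1ccc(C(F)(F)F)cc1`: 66000 nM

All three compounds were tested in a functional assay for inhibition (a lower number here means a stronger inhibitor, a higher number a weaker inhibitor), and their numbers lie together. Compound 3 gives 66000 nM there, level with the other two within the scatter.

Compound 4 `CCNC(=O)Nc1ccc(S(=O)(=O)Nc2cc(F)c(O)c(F)c2)cc1` has not yet been measured. It keeps the shared core and carries (ethylcarbamoyl)amino in place of trifluoromethyl on an aromatic carbon, para to a large group ((ethylcarbamoyl)amino in place of trifluoromethyl on an aromatic carbon). Within the data shown here, two measured steps bear on this change. The closer one changes the same place: the step of a 1.0-fold lower number from compound 1 to compound 3 (0.02 log units; within the scatter) puts trifluoromethyl in place of benzamido and stays within the scatter. The other, a 1.0-fold higher number from compound 1 to compound 2 (0.01 log units; within the scatter), puts methoxy in place of hydrogen on an aromatic carbon and also stays within the scatter. Among the measured compounds shown here, no measured compound carries (ethylcarbamoyl)amino, so this group itself is untested, and three compounds make a thin basis. Even so, neither step gives any reason to expect a real shift in this assay. The expected change is a 1.1-fold lower number from compound 3 to compound 4 (0.04 log units; within the scatter), which means no step beyond the scatter in either direction. For compound 4 the estimated value is 60000 nM, with an expected range from 25000 nM to 125000 nM.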

Compound 4, half-maximal inhibitory concentration: 81700 nM
Compound 4: middle estimate off by 1.4-fold (0.13 log units), on the low side; measured number inside the range.
By their numbers in this assay, from the lowest: compounds 3, 1, 2 and 4 (each within the scatter of the next).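

In this assay, (ethylcarbamoyl)amino in place of trifluoromethyl gives a 1.2-fold higher number from compound 3 to compound 4 (0.09 log units; within the scatter), so bringing hydrogen-bond donors and a hydrogen-bond acceptor onto this aromatic carbon, para to a large group, produces no step beyond the scatter. Among these compounds, the change also reaches the substituent on the carbonyl carbon for the first time: ethylamino in place of phenyl gives a 1.2-fold higher number from compound 1 to compound 4 (0.08 log units; within the scatter) and ethylamino in place of 4-methoxyphenyl gives a 1.2-fold higher number from compound 2 to compound 4 (0.06 log units; within the scatter), which shows that the number holds without an aromatic ring on that carbonyl carbon. Nothing presented accounts for this lack of response.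

Going by these compounds, all four compounds lie together, so it remains open whether any other group here, such as an amine, a carboxylic acid or a longer chain on the carbonyl carbon, could move the number beyond the scatter in either direction. On these data alone, the hydroxyl and the fluorine atoms of the shared core are the same throughout, so their part in this level of inhibition also remains open.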